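Furan-2-yl for thiophen-2-yl on the tetrahydropyranyl series

The compounds below may be only part of what the source reports. "The series", "measured", "known", "first", "only" and "open" are said of these compounds alone.

In a functional assay on K562 cells (Homo sapiens), read by thymidine incorporation (a higher number here means a weaker inhibitor, a lower number a stronger inhibitor), compound 1 `C=CCn1cnc2c(-c3ccco3)ncnc21` gives 11 ug/mL. For compound 2 `c1ccc(-c2ncnc3c2ncn3C2CCOCC2)cc1` this assay reports only a limit, < 10 ug/mL. Compound 3 `c1csc(-c2ncnc3c2ncn3C2CCOCC2)c1` gives 23 ug/mL in this assay, the highest of the two numbers measured; compound 1 sits below it. Among the compounds with values here, the single step measured in one place, an at least 2.3-fold higher number from compound 2 to compound 3 (0.36 log units; beyond the scatter), rests on that limit of < 10 ug/mL in this assay, at which 1 of the 3 values shown sits, and so its full size is open. Compound 4 `c1coc(-c2ncnc3c2ncn3C2CCOCC2)c1` differs from compound 3 by furan-2-yl in place of thiophen-2-yl on an aromatic carbon. Within the data shown here, no measured step swaps these two rings directly. Compound 1 also carries furan-2-yl and its number lies under that of compound 3, but compound 1 differs from compound 4 at the other ring, so it serves only as a loose pointer. Among the measured compounds shown here, with an oxygen-for-sulfur swap of this kind and no direct precedent, the expectation in this assay is a small move downward, close to the edge of the scatter. Compound 4 is expected at 14 ug/mL, with a range of 6 ug/mL to 30 ug/mL. This estimate means an expected step of a 1.6-fold lower number from compound 3 to compound 4 (0.22 log units; within the scatter).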

Compound 4, half-maximal inhibitory concentration: 15 ug/mL
Estimate against measurement, compound 4: 1.1-fold (0.03 log units) below; low and high end bracket the measured number.
By their numbers in this assay, from the lowest: compounds 1, 4 and 3 (each within the scatter of the next, the first and the last beyond it). At a limit, below all of these: compound 2.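

In this assay, within the data shown here, the first direct swap at this position, on an aromatic carbon of the six-membered ring, gives a 1.5-fold lower number from compound 3 to compound 4 (0.19 log units; within the scatter), so furan-2-yl and thiophen-2-yl are not separated here. With furan-2-yl held fixed, the change on the aromatic nitrogen gives a 1.4-fold higher number from compound 1 to compound 4 (0.13 log units; within the scatter), so oxan-4-yl and allyl are not separated either. Compound 2 stands only at a limit, so the comparison of phenyl with furan-2-yl yields just a floor, an at least 1.5-fold higher number from compound 2 to compound 4 (0.17 log units; that floor lies within the scatter): the limit of < 10 ug/mL in this assay, at which 1 of the 4 values shown sits.

Still open, from the compounds shown here alone, is whether an amine or a carboxylic acid on the furan-2-yl ring would move the number beyond the scatter. Also open, going by these compounds, is how far the true number for phenyl lies from those of the two five-membered rings.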